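The source may report more compounds than this note shows. Statements on the series, on what has been measured and on what is new or still open speak of the compounds shown alone.

Measured compounds in an assay on isolated protein for antagonist activity at Bile acid receptor (Homo sapiens), read by HTRF, with a stated time of 30 min; a lower number here means a stronger inhibitor, a higher number a weaker inhibitor:
Compound 1, `CCc1cc(C(=O)C(C)C)c(O)cc1OCCCCCC(C)(C)c1nnn[nH]1`: 8600 nM
Compound 2, `CCCCC(=O)c1cc(CC)c(OCCCCCC(C)(C)c2nnn[nH]2)cc1O`: 5400 nM

Compound 2 holds the lower of the two numbers, yet the step of a 1.6-fold lower number from compound 1 to compound 2 (0.20 log units; within the scatter) stays within the scatter, so the two compounds are not told apart by these data. The change behind that step was a butyl chain on the carbonyl carbon in place of an isopropyl group.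

Compound 3, `CCCCCCC(=O)c1cc(CC)c(OCCCCCC(C)(C)c2nnn[nH]2)cc1O`, has not yet been measured. It differs from compound 2 by ethyl in place of hydrogen on a saturated chain carbon, four bonds along the chain from a carbonyl carbon. Within the data shown here, the only measured step that bears on this change is the earlier lengthening of the same chain on the carbonyl carbon, which was small. Compound 3 is therefore expected to differ from compound 2 by only a small step, a 1.4-fold lower number from compound 2 to compound 3 (0.13 log units; within the scatter), downward if at all, and quite possibly none beyond the scatter. In this assay compound 3 is expected to give about 4000 nM, within a range from 1500 nM to 12000 nM.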

Compound 3, half-maximal inhibitory concentration: 8400 nM
Compound 3: middle estimate off by 2.1-fold (0.32 log units), on the low side; the measured number falls inside the stated range.
By their numbers in this assay, from the lowest: compounds 2, 3 and 1 (each within the scatter of the next).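

In this assay, ethyl in place of hydrogen on a saturated chain carbon, four bonds along the chain from a carbonyl carbon, gives a 1.6-fold higher number from compound 2 to compound 3 (0.19 log units; within the scatter), so this longer chain is not told apart from the butyl chain of compound 2. The remaining comparison on the carbonyl carbon gives a 1.0-fold lower number from compound 1 to compound 3 (0.01 log units; within the scatter), so with three compounds now in hand, isopropyl, butyl and hexyl on that carbon show no trend with chain length, and the small gap first seen between compound 1 and compound 2 does not grow into one. Nothing measured here offers an explanation for this flat result.

On these data alone, whether any group on the carbonyl carbon can move the number beyond the scatter remains open. An amine or a carboxylic acid at the end of the chain, or a phenyl ring in place of hexyl, would test this, as would a chain longer than hexyl.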